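Trifluoromethyl Added to the Fluorophenyl Chalcone

The compounds below may be only part of what the source reports. "The series", "measured", "known", "first", "only" and "open" are said of these compounds alone.

Compound 1 `CC1=CCCC(C)(C)C1/C=C/C(=O)/C=C/c1cccc(C(F)(F)F)c1` and compound 2 `CC1=CCCC(C)(C)C1/C=C/C(=O)/C=C/c1ccccc1F` share a dienone core and differ only in the aryl substituent. In a functional assay on PC-3 cells (Homo sapiens) for cytotoxicity, read by MTT assay, with a stated time of 72 h (on this read-out lower numbers stand for stronger inhibition and higher numbers for weaker inhibition), compound 1 gives 5200 nM and compound 2 gives 4800 nM; the two values stand within the scatter of each other, so no order between them can be read. Compound 3 `CC1=CCCC(C)(C)C1/C=C/C(=O)/C=C/c1cc(C(F)(F)F)ccc1F` carries the change (trifluoromethyl in place of hydrogen on an aromatic carbon), trifluoromethyl in place of hydrogen on an aromatic carbon. Because compound 1 already carries trifluoromethyl at 5200 nM, the step is expected to be a 1.2-fold lower number from compound 2 to compound 3 (0.08 log units; within the scatter), not beyond the scatter. Compound 3 is estimated at 4000 nM, range 1500 nM to 12000 nM.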

Compound 3, half-maximal inhibitory concentration: 3100 nM
Beside the measured number, compound 3's estimate is 1.3-fold (0.11 log units) above it; measured number inside the range.
By their numbers in this assay, from the lowest: compounds 3, 2 and 1 (each within the scatter of the next).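

In this assay, trifluoromethyl on the aromatic carbon para to the fluoro group gives a 1.5-fold lower number from compound 2 to compound 3 (0.19 log units; within the scatter), and fluoro in place of hydrogen gives a 1.7-fold lower number from compound 1 to compound 3 (0.22 log units; within the scatter), with both steps within the scatter. Carrying both groups on one ring therefore does not separate compound 3 from either compound with a single group. No evidence on the cause bears on this result. On these data alone, whether an amine or a carboxylic acid on this aromatic carbon would give a step beyond the scatter remains open. So does the outcome of replacing the fluoro group with a methoxy group.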